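Replacing 4-hydroxy-2-methylphenyl with 4-ethylphenyl

The source may hold more compounds than are shown below. What is called first, only, known or untested is meant among the compounds shown, and "the series" means these compounds.

Two compounds have been measured in a functional assay on OVCAR-5 cells (Homo sapiens) for inhibition, read by sulforhodamine B assay, with a stated time of 48 h (a higher number here means a weaker inhibitor of growth, a lower number a stronger inhibitor of growth), so far
compound 1 `Cc1ccc(C2=NN(c3ccc(S(C)(=O)=O)cc3)C(=O)CC2)cc1` gives 3690 nM
compound 2 `Cc1cc(O)ccc1C1=NN(c2ccc(S(C)(=O)=O)cc2)C(=O)CC1` gives 53800 nM

For the measured compounds named here, of the two, compound 2 holds the higher number at 53800 nM and compound 1 is its only neighbour. Compound 3 `CCc1ccc(C2=NN(c3ccc(S(C)(=O)=O)cc3)C(=O)CC2)cc1` carries 4-ethylphenyl in place of 4-hydroxy-2-methylphenyl on a carbon with a double bond to nitrogen while the shared core stays the same. Going by the values given here, the one measured step at this place, a large one beyond the scatter, is a 15-fold higher number from compound 1 to compound 2 (1.16 log units; beyond the scatter) and it came with 4-hydroxy-2-methylphenyl in place of 4-methylphenyl. Compound 3 no longer carries 4-hydroxy-2-methylphenyl, so a large step down in this assay is expected, towards compound 1 at 3690 nM as the guide. The expected change is an 18-fold lower number from compound 2 to compound 3 (1.25 log units; beyond the scatter) by this estimate. For compound 3 the estimated value is 3000 nM with an expected range from 1000 nM to 9000 nM in repeat measurements.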

Compound 3, concentration for 50% growth inhibition: 8510 nM
Compound 3: middle estimate off by 2.8-fold (0.45 log units), on the low side; the range from low to high includes it.
By their numbers in this assay, from the lowest: compound 1; then compound 3; then compound 2.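

In this assay, the extra carbon at this place has a cost of its own: a 2.3-fold higher number from compound 1 to compound 3 (0.36 log units; beyond the scatter), a modest step beyond the scatter, comes with methyl in place of hydrogen on the saturated chain carbon bound to the aromatic carbon. Removing 4-hydroxy-2-methylphenyl in favour of 4-ethylphenyl gives a 6.3-fold lower number from compound 2 to compound 3 (0.80 log units; beyond the scatter), so the large loss seen with compound 2 is partly recovered, yet not fully, as compound 3 stays short of compound 1 at this place. The position therefore responds to a small change in the para-free wording of the chain alone, with no hydroxyl involved in that step.

Still open, on these data alone, is how the hydroxyl and the 2-methyl each contribute in compound 2, and how a longer chain such as propyl, or an amine, would read here. No measurement on hand explains any of these steps.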